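The source may hold more compounds than are shown below. What is called first, only, known or untested is meant among the compounds shown, and "the series" means these compounds.

Compounds 1, 2 and 3 were tested in a functional assay on MCF7 cells (Homo sapiens) for cytotoxicity, read by MTT assay, with a stated time of 72 h; a higher number here means a weaker inhibitor, a lower number a stronger inhibitor. Compound 1 `CNC(=O)c1cc(Oc2ccc(NC(=O)c3nn(-c4ccc(C)cc4)c(=O)cc3C)cc2F)ccn1` gives 8380 nM. Compound 2 `Cc1ccc(-n2nc(C(=O)Nc3ccc(Oc4ncnc5ccsc45)c(F)c3)c(C)cc2=O)cc1` gives 7250 nM, and the move a 1.2-fold lower number from compound 1 to compound 2 (0.06 log units; within the scatter) swaps the group that hangs on the aromatic ether oxygen. For compound 3 `Cc1cc(=O)n(-c2ccccc2OC(F)(F)F)nc1C(=O)Nc1ccc(Oc2ncnc3sccc23)c(F)c1` only a limit is reported, at > 40000 nM, so compound 3 stands apart from the other two, at the weak end of what this assay can resolve, as noted in the limit of > 40000 nM in this assay, at which 1 of the 3 values shown sits.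

Compound 4 `Cc1ccc(-n2nc(C(=O)Nc3ccc(Oc4ncnc5sccc45)c(F)c3)c(C)cc2=O)cc1` has not yet been measured. It differs from compound 3 in one place: 4-methylphenyl in place of 2-(trifluoromethoxy)phenyl on an aromatic nitrogen. Going by the values given here, the only measured step, from compound 1 to compound 2, concerns a different part of the molecule and gives no direct guide, and no step touching the group on the aromatic nitrogen has been measured. Compound 2 does carry the same 4-methylphenyl group as compound 4 and sits at a plain number rather than a limit, so compound 4 is expected to move from the limit of compound 3 into the measurable range, a step of about an at least 5.0-fold lower number from compound 3 to compound 4 (0.69 log units; beyond the scatter) toward stronger inhibition. For compound 4 the estimated value is 8000 nM, with a range from 3000 nM to 30000 nM.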

Compound 4, half-maximal inhibitory concentration: > 40000 nM
Compound 4: a limit, no number (the forecaster's own chance of this, stated with the estimate: 15%); middle value at least 5.0-fold (0.69 log units) away from the limit.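

With the 4-methylphenyl group held fixed, the group on the ether oxygen proves to matter in this assay: two groups with the same atom counts and ring types, differing only in how those rings are arranged, give an at least 5.5-fold higher number from compound 2 to compound 4 (0.74 log units; beyond the scatter). A second comparison on that oxygen gives an at least 4.7-fold higher number from compound 1 to compound 4 (0.67 log units; beyond the scatter), even though the earlier swap there, a 1.2-fold lower number from compound 1 to compound 2 (0.06 log units; within the scatter), had produced no real change, so a flat step for one replacement does not carry over to a closely related one. Compound 3 and compound 4 both rest at a limit of the assay, so the step between them cannot be read and the swap on the aromatic nitrogen remains unresolved: the limit of > 40000 nM in this assay, at which 2 of the 4 values shown sit.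

From the compounds shown here alone, what the group on the aromatic nitrogen contributes therefore stays open. A 4-chlorophenyl or a plain phenyl there, with the rest of compound 2 unchanged, would give a comparison against a value that is not a limit.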